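Triazole aryl swap in a weakly antiproliferative spirooxindole series

A few compounds are considered here, and "the series" means these few. Any claim that something is new, unique, unknown or untested is made for them only; others in the source may bear on it.

Compound 1, `Cc1cc(C)cc(-n2nncc2CN2C(=O)C3(C(C#N)=C(N)Oc4c3c3nc5ccccc5nc3c3ccccc43)c3ccccc32)c1`, gives > 50000 nM in an ADME assay on HUVEC cells (Homo sapiens) for antiproliferative activity, read by MTT assay, with a stated time of 48 h (on this read-out lower numbers stand for stronger inhibition and higher numbers for weaker inhibition), which is a limit of the assay rather than a number.
Compound 2, `N#CC1=C(N)Oc2c(N)cc3nc4ccccc4nc3c2C12C(=O)N(Cc1cnnn1-c1ccccc1Cl)c1ccccc12`, gives > 50000 nM, also a limit.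
Compound 3, `N#CC1=C(N)Oc2c(N)cc3nc4ccccc4nc3c2C12C(=O)N(Cc1cnnn1-c1ccccc1Br)c1ccccc12`, gives 34200 nM.

Among the compounds with values here, compound 3 thus holds the only numerical value shown; the other two sit at the limit (the limit of > 50000 nM in this assay, at which 2 of the 3 values shown sit). Compound 4, `Cc1cc(C)cc(-n2nncc2CN2C(=O)C3(C(C#N)=C(N)Oc4c(N)cc5nc6ccccc6nc5c43)c3ccccc32)c1`, differs from compound 3 in one place: 3,5-dimethylphenyl in place of 2-bromophenyl on an aromatic nitrogen. Within the data shown here, the only measured step, an at least 1.4-fold lower number from compound 2 to compound 3 (0.16 log units; that floor lies within the scatter), exchanges one halogen for another and lies within the scatter, so it gives little guidance for replacing the whole 2-bromophenyl by 3,5-dimethylphenyl. No shift beyond the scatter is therefore expected. Compound 4 is estimated at 45000 nM in this assay, between 20000 nM and 100000 nM. That estimate means a step of a 1.3-fold higher number from compound 3 to compound 4 (0.12 log units; within the scatter), with a fair chance that only a limit is returned.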

Compound 4, half-maximal inhibitory concentration: > 50000 nM
Compound 4: only a limit was reported; the forecaster's own chance of this, stated with the estimate: 55%; middle value at least 1.1-fold (0.04 log units) from the limit.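

On these data alone, putting 3,5-dimethylphenyl in place of 2-bromophenyl on the aromatic nitrogen gives an at least 1.4-fold higher number from compound 3 to compound 4 (0.16 log units; that floor lies within the scatter); compound 4 returns only a limit, so the true size of this step stays unknown. The step between compound 2 and compound 4 cannot be read, as both values are limits. Exchanging the whole aryl group therefore brought no measurable gain, and most of the series now sits at the same limit: the limit of > 50000 nM in this assay, at which 3 of the 4 values shown sit.

Still open, as far as these compounds go, is whether an aryl ring carrying an amine or a carboxylic acid, or a longer chain in place of the aryl ring, would give a number clearly under that limit.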